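Sulfonyl Aryl Swap in a Piperidinyl-Piperidine Sulfonamide Series

The source may hold more compounds than are shown below. What is called first, only, known or untested is meant among the compounds shown, and "the series" means these compounds.

Compound 1 `Cc1noc(C)c1S(=O)(=O)N1CCC(N2CCC(C)CC2)CC1` in an ADME assay on HCT-116 cells (Homo sapiens) for cytotoxicity, read by CellTiter-Glo, with a stated time of 72 h (a higher number here means a weaker inhibitor, a lower number a stronger inhibitor), gives > 10000 nM, a limit of the assay and not a number.
Compound 2 `CC1CCN(C2CCN(S(=O)(=O)c3ccc(C#N)cc3)CC2)CC1` in this assay gives > 5000 nM, likewise a limit.
Compound 3 `CC1CCN(C2CCN(S(=O)(=O)c3nccn3C)CC2)CC1` in this assay gives > 10000 nM, again a limit.

All three measured compounds of this series share a core and differ only in the group on the sulfonyl sulfur. For the measured compounds named here, every value recorded so far is a limit; compound 3 sits at the limit of > 10000 nM in this assay, at which 2 of the 3 values shown sit, and no step among the measured pairs can be sized, as a step that the two limits leave unreadable from compound 1 to compound 2, a step that the two limits leave unreadable from compound 1 to compound 3 and a step that the two limits leave unreadable from compound 2 to compound 3 all show. Against this background stands compound 4 `CC1CCN(C2CCN(S(=O)(=O)c3cccc(Br)c3)CC2)CC1`, which is not yet measured. Its change from compound 3 is 3-bromophenyl in place of 1-methyl-1H-imidazol-2-yl on a sulfonyl sulfur. Going by the values given here, the steps that bear on it, each a swap of the group on the sulfonyl sulfur, are all unreadable, so their size gives no direction for this assay; the only guidance is that every measured variant of this group stayed at a limit, whether the limit of > 10000 nM in this assay, at which 2 of the 3 values shown sit, or (the limit of > 5000 nM in this assay, at which 1 of the 3 values shown sits). Compound 4 is therefore expected to stay at or near the limit as well, with a number no higher from compound 3 to compound 4 (the limit leaves the size open) estimated as no step beyond the scatter. The estimate for compound 4 in this assay is 10000 nM, within 3000 nM to 30000 nM.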

Compound 4, half-maximal inhibitory concentration: > 5000 nM
Compound 4: only a limit was reported; the forecaster's own chance of this, stated with the estimate: 80%; the middle value is on the limit's open side.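

Compound 4 gives > 5000 nM in this assay, a limit of the assay and not a number. The steps to compound 4 from compound 1, compound 2 and compound 3 therefore cannot be read. The compounds shown leave open whether any group on the sulfonyl sulfur gives a numerical half-maximal inhibitory concentration in this assay, and how these four compounds rank.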